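Compound 2 to Compound 4: Furan Swap on the Catechol Core

The source may hold more compounds than are shown below. What is called first, only, known or untested is meant among the compounds shown, and "the series" means these compounds.

Compound 1 `O=C(/C=C/c1ccsc1)c1cc(O)c(O)c([N+](=O)[O-])c1` gives 41400 nM in an assay on isolated protein for inhibition of Amine oxidase [flavin-containing] A (Homo sapiens), read by fluorescence; a higher number here means a weaker inhibitor, a lower number a stronger inhibitor.
Compound 2 `CC(=O)N1N=C(c2cc(O)c(O)c([N+](=O)[O-])c2)CC1c1ccco1` gives 98000 nM in this assay.
Compound 3 `N#Cc1cccc(/C=C/C(=O)c2cc(O)c(O)c([N+](=O)[O-])c2)c1` gives 58900 nM in this assay.

Of the three numbers, that of compound 2 is the highest. Its gap to compound 3 lies within the usual scatter of repeated measurements, so the two cannot be told apart; its gap to compound 1 lies beyond the scatter. For the measured compounds named here, no pair of measured compounds differs in a single place, so no measured step is available to guide the next one.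

Compound 4 `CC(=O)N1N=C(c2cc(O)c(O)c([N+](=O)[O-])c2)CC1c1ccoc1` differs from compound 2 by furan-3-yl in place of furan-2-yl on a saturated ring carbon. The two compounds have the same atoms, joined differently. Going by the values given here, with nothing among the measured compounds to indicate otherwise, the step from compound 2 to compound 4 in this assay is expected to be small, not beyond the scatter, in either direction: a 1.1-fold lower number from compound 2 to compound 4 (0.04 log units; within the scatter). Compound 4 is therefore estimated at 90000 nM, with a range from 40000 nM to 200000 nM.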

Compound 4, half-maximal inhibitory concentration: 90900 nM
For compound 4 the middle estimate is 1.0-fold (0.00 log units) below the measured one, and the stated range covers the measured number.
By their numbers in this assay, from the lowest: compounds 1, 3, 4 and 2 (each within the scatter of the next, the first and the last beyond it).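

In this assay, for the compounds shown here, furan-3-yl in place of furan-2-yl on a saturated ring carbon gives a 1.1-fold lower number from compound 2 to compound 4 (0.03 log units; within the scatter), the first step here between compounds that differ in one place. At this position, then, the two ways of joining the furan cannot be told apart, although the two compounds have the same atoms joined differently. Nothing available here accounts for this result.

The compounds shown leave open whether a group other than furan at this saturated ring carbon, such as a phenyl ring or a morpholine, would move the number beyond the scatter. They also leave open whether a longer chain in place of the acetyl group on the ring nitrogen would change the number in this assay at all.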